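Fluoro for methoxy on a shared diamino core

The source may report more compounds than this note shows. Statements on the series, on what has been measured and on what is new or still open speak of the compounds shown alone.

Of the compounds shown here, three built on the same core have been measured in a functional assay on COLO 205 cells (Homo sapiens) for inhibition, read by sulforhodamine B assay, with a stated time of 48 h; on this read-out higher numbers stand for weaker inhibition of growth and lower numbers for stronger inhibition of growth. Compound 1, `Nc1cc(N)c2nc(-c3ccccc3)c(NCc3ccc(Cl)c(Cl)c3)nc2c1`, gives 17000 nM. Compound 2, `CCOC(=O)[C@H](CCC(=O)O)NC(=O)c1ccc(Oc2nc3cc(N)cc(N)c3nc2-c2ccccc2)cc1`, gives 30200 nM. Compound 3, `COc1ccc(Sc2nc3cc(N)cc(N)c3nc2-c2ccccc2)cc1`, gives 19500 nM. The number for compound 3 sits between those of the other two, and its gap to compound 1 as well as its gap to compound 2 lies within the usual scatter of repeated measurements, so the three values cannot be told apart with confidence.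

Compound 4, `Nc1cc(N)c2nc(-c3ccccc3)c(Sc3ccc(F)cc3)nc2c1`, has not yet been measured. It differs from compound 3 in one place: fluoro in place of methoxy on an aromatic carbon. The change is small in atom count and removes one hydrogen-bond acceptor; nothing else in the molecule moves.

For the measured compounds named here, no measured pair here differs by this change, so there is no step to lean on. With the three measured values lying so close together, the expectation is that the step from compound 3 to compound 4 stays within the scatter, in no particular direction, and is estimated as a 1.0-fold higher number from compound 3 to compound 4 (0.01 log units; within the scatter). Compound 4 is therefore expected to give about 20000 nM in this assay, with a range from 8000 nM to 50000 nM.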

Compound 4, concentration for 50% growth inhibition: 21900 nM
Compound 4: the middle estimate sits 1.1-fold (0.04 log units) below what was measured, within the range that was stated.
By their numbers in this assay, from the lowest: compounds 1, 3, 4 and 2 (each within the scatter of the next).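

For the compounds shown here, the pair compound 3 and compound 4 is the first in this set to differ in one place, so it gives the first direct reading of a single change on the shared core. In this assay, going from 4-methoxyphenyl to 4-fluorophenyl on the sulfanyl group gives a 1.1-fold higher number from compound 3 to compound 4 (0.05 log units; within the scatter), so at this aromatic carbon, fluoro in place of methoxy, a swap that takes away one hydrogen-bond acceptor, leaves the number within the scatter. Nothing available here speaks to why the number holds.

This single pair leaves open whether other groups on the same aromatic carbon, such as an amine, a carboxylic acid or a longer alkoxy chain, would shift the number beyond the scatter. It also leaves open whether the sulfur link itself matters, since the compounds shown hold no pair in which an oxygen or an amine link replaces that sulfur while the rest of the molecule stays the same.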